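Compound 3: replacing piperidin-1-yl with 1-benzofuran-2-yl

The source may hold more compounds than are shown below. What is called first, only, known or untested is meant among the compounds shown, and "the series" means these compounds.

Measured so far in a toxicity assay on NIH3T3 cells (Mus musculus) for cytotoxicity, read by resazurin assay; a higher number here means that more compound is needed for the effect, a lower number that less compound is needed (both values are limits):
- compound 1 `Clc1ccc(NCc2cncn2Cc2ccc(-c3ccccc3)cc2)cc1-c1ccccc1` gives > 1000 nM
- compound 2 `c1ccc(-c2ccc(Cn3cncc3CNc3ccc(N4CCCCC4)c(-c4ccccc4)c3)cc2)cc1` gives > 1000 nM

In this assay compound 2 gives > 1000 nM, which is a limit and not a number. The record so far amounts to the limit of > 1000 nM in this assay, at which 2 of the 2 values shown sit. Compound 3 `c1ccc(-c2ccc(Cn3cncc3CNc3ccc(-c4cc5ccccc5o4)c(-c4ccccc4)c3)cc2)cc1` departs from compound 2 at one place, with 1-benzofuran-2-yl in place of piperidin-1-yl on an aromatic carbon. Among the measured compounds shown here, the one measured step at this place is a step that the two limits leave unreadable from compound 1 to compound 2, so it offers no size to carry forward. No definite size or direction of change can be expected in this assay, and only a value near the limit seems a fair expectation. The expected change is a step that the limit leaves unreadable from compound 2 to compound 3. For compound 3 the estimated value is 2000 nM, with an expected range of 700 nM to 6000 nM.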

Compound 3, half-maximal effective concentration: > 10000 nM
Compound 3 gave a limit, no number; the forecaster's own chance of this, stated with the estimate: 70%; at least 5.0-fold (0.69 log units) between middle value and limit.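

In this assay, among the compounds shown here, the results for compound 1, compound 2 and compound 3 are all limits, not numbers, so no step among them can be read. The compounds shown leave open what concentration each one actually needs, and whether exchanging the group at this place changes it.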